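Compound 3 to compound 4: methyl to methoxy

The compounds below may be only part of what the source reports. "The series", "measured", "known", "first", "only" and "open" are said of these compounds alone.

Compound 1 `CC1(C)[C@H]2CC[C@]1(C)N(Cc1cn(-c3ccccc3Br)nn1)C(=O)C2`: 150 nM
Compound 2 `CC1(C)[C@H]2CC[C@]1(C)N(Cc1cn(-c3cccc(C#N)c3)nn1)C(=O)C2`: 40 nM
Compound 3 `Cc1ccc(-n2cc(CN3C(=O)C[C@@H]4CC[C@@]3(C)C4(C)C)nn2)cc1`: 480 nM

In a functional assay on HepG2 cells (Homo sapiens) for inhibition, read by MTT assay, with a stated time of 24 h (on this read-out higher numbers stand for weaker inhibition and lower numbers for stronger inhibition), compound 3 at 480 nM has the highest number of the three and is the weakest so far. Compound 4 `COc1ccc(-n2cc(CN3C(=O)C[C@@H]4CC[C@@]3(C)C4(C)C)nn2)cc1` differs from it by methoxy in place of methyl on an aromatic carbon, para to a large group.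

Going by the values given here, no measured step makes this exact exchange. The closest evidence comes from the three steps that change the phenyl group on the aromatic nitrogen: a 3.8-fold lower number from compound 1 to compound 2 (0.57 log units; beyond the scatter), a 3.2-fold higher number from compound 1 to compound 3 (0.51 log units; beyond the scatter) and a 12-fold higher number from compound 2 to compound 3 (1.08 log units; beyond the scatter). All three lie beyond the scatter, but each also changes the substituent's position, whereas this change keeps it in place. A modest step towards a lower number is therefore expected in this assay, though one within the scatter remains possible. The estimated step is a 1.6-fold lower number from compound 3 to compound 4 (0.20 log units; within the scatter). The estimate for compound 4 is 300 nM, with an expected range of 100 nM to 800 nM.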

Compound 4, half-maximal inhibitory concentration: 100 nM
Compound 4: middle estimate off by 3.0-fold (0.48 log units), on the high side, within the range that was stated.
By their numbers in this assay, from the lowest: compound 2; then compounds 4 and 1 (each within the scatter of the next); then compound 3.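

In this assay, the step of a 4.8-fold lower number from compound 3 to compound 4 (0.68 log units; beyond the scatter) is the only one shown that changes the group while keeping its place on the phenyl ring, so this single exchange on the aromatic carbon moves the number beyond the scatter without any shift in position. Compound 4 is not separated from the 2-bromophenyl compound, with a 1.5-fold lower number from compound 1 to compound 4 (0.18 log units; within the scatter), but it stays apart from the 3-cyanophenyl compound, with a 2.5-fold higher number from compound 2 to compound 4 (0.40 log units; beyond the scatter), so methoxy at this place does not reach the lowest number in the set. Nothing available explains why this exchange has the effect it does.

Open, on these data alone, is whether the oxygen itself matters, which a hydroxy or ethyl group at the same place could separate from the added heavy atom. Also open, as far as these compounds go, is how a nitrile in place of the methoxy would compare with compound 2.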